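Methoxy on the Benzyl Arm: From Compound 2 to Compound 3

A few compounds are considered here, and "the series" means these few. Any claim that something is new, unique, unknown or untested is made for them only; others in the source may bear on it.

In a functional assay on A-375 cells (Homo sapiens) for antiproliferative activity, read by MTT assay, with a stated time of 48 h (a higher number here means a weaker inhibitor, a lower number a stronger inhibitor), two compounds built on one shared core have been measured. Compound 1 `CCCCCCc1nc(N)n(CC(=O)Nc2ccc(C)cc2)c1-c1ccccc1Br` gives 5100 nM, and compound 2 `Cc1ccc(NC(=O)Cn2c(N)nc(Cc3ccccc3)c2-c2ccccc2Br)cc1` gives 2000 nM. Among the compounds with values here, the single measured step between them, a 2.6-fold lower number from compound 1 to compound 2 (0.41 log units; beyond the scatter), leaves compound 2 with the lowest of the two numbers, its nearest neighbour being compound 1.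

Compound 3 `COc1ccc(Cc2nc(N)n(CC(=O)Nc3ccc(C)cc3)c2-c2ccccc2Br)cc1` differs from compound 2 in one place: methoxy in place of hydrogen on an aromatic carbon. Within the data shown here, no measured step touches a change of this kind. Among the measured compounds shown here, the only step available, a 2.6-fold lower number from compound 1 to compound 2 (0.41 log units; beyond the scatter), exchanged one group for another of a different sort and says nothing about turning benzyl into 4-methoxybenzyl. For the measured compounds named here, with no step bearing on it, the expected change in this assay is none beyond the scatter, in either direction, and the number for compound 3 is estimated close to that of compound 2.

Compound 3 is therefore expected to give 2000 nM, with a range from 800 nM to 5000 nM, which means an expected step of no change at the digits printed from compound 2 to compound 3 (within the scatter) that stays within the usual scatter.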

Compound 3, half-maximal inhibitory concentration: 2400 nM
The estimate for compound 3 lay 1.2-fold (0.08 log units) below the measured number; low and high end bracket the measured number.
By their numbers in this assay, from the lowest: compounds 2 and 3 (each within the scatter of the next); then compound 1.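

In this assay, within the data shown here, methoxy in place of hydrogen on an aromatic carbon, para to a large group, gives a 1.2-fold higher number from compound 2 to compound 3 (0.08 log units; within the scatter), so this position of the benzyl arm takes methoxy without a change that can be told from the scatter, which the earlier compounds could not show, since neither carried a group on that ring. The advantage over the pentyl chain also holds with methoxy present: the change to 4-methoxybenzyl gives a 2.1-fold lower number from compound 1 to compound 3 (0.33 log units; beyond the scatter), and this step, like the change to benzyl with a 2.6-fold lower number from compound 1 to compound 2 (0.41 log units; beyond the scatter), lies beyond the scatter. Nothing measured here offers an explanation for the result.

Going by these compounds, one methoxy group at one position cannot show whether this carbon accepts any group without consequence, so it remains open whether an amine, a carboxylic acid or a chlorine atom there would also stay within the scatter of compound 2. On these data alone, it is equally open whether methoxy would give the same result on another carbon of that ring, and whether a longer chain in place of the benzyl arm would keep the advantage over compound 1.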